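The source may report more compounds than this note shows. Statements on the series, on what has been measured and on what is new or still open speak of the compounds shown alone.

Working notes on the series. Within the data shown here, in a physicochemical assay for solubility, using the shake flask method, in phosphate buffer, measured as kinetic solubility, with a stated time of 20 h, at pH 6.5 (a higher number here means a more soluble compound, a lower number a less soluble compound), compound 2 `FC(F)(F)c1ccc(Nc2cc3[nH]c(C4CCCC4)nc3cn2)nc1` gives 145000 nM, the only full number in hand. Compound 1 `Fc1ccc(-c2nc3cnc(Nc4ccccn4)cc3[nH]2)cc1F` returns < 5000 nM in this assay, a limit rather than a number, namely (the limit of < 5000 nM in this assay, at which 1 of the 2 values shown sits). Compound 3 `CC1(c2nc3cnc(Nc4ccc(C(F)(F)F)cn4)cc3[nH]2)CC1` is not yet measured in this assay and differs from compound 2 by 1-methylcyclopropyl in place of cyclopentyl on an aromatic carbon. Among the measured compounds shown here, no measured step is available to set a size, so the expected change in this assay is small, within the usual scatter, with no firm direction. The expected value for compound 3 in this assay is 150000 nM, ranging from 60000 nM to 350000 nM. The step from compound 2 to compound 3 is expected to be a 1.0-fold higher number from compound 2 to compound 3 (0.01 log units; within the scatter).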

Compound 3, solubility: 188000 nM
For compound 3 the middle estimate is 1.3-fold (0.10 log units) below the measured one; low and high end bracket the measured number.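

In this assay, among these compounds, the first measured step at this position, on an aromatic carbon between two ring nitrogen atoms, is a 1.3-fold higher number from compound 2 to compound 3 (0.11 log units; within the scatter). Exchanging cyclopentyl for 1-methylcyclopropyl therefore gives values that cannot be told apart in this assay, so this position tolerates this one change without a resolved shift. No measurement shown bears on why the step has this size. Still open, on these data alone, is whether an amine, a carboxylic acid or a longer alkyl chain at this position would give a step beyond the scatter.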